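The source may hold more compounds than are shown below. What is called first, only, known or untested is meant among the compounds shown, and "the series" means these compounds.

Working notes on the series. Compound 3 `O=C(/C=C/c1ccc(O)cc1)c1c(O)cccc1OCC1CCCC1` gives 3410 nM in a functional assay on MDA-MB-231 cells (Homo sapiens) for antiproliferative activity, read by sulforhodamine B assay; a higher number here means a weaker inhibitor of growth, a lower number a stronger inhibitor of growth. Compound 2 `CC(C)(C)CCOc1cccc(O)c1C(=O)/C=C/c1ccc(C(=O)O)cc1` gives 11200 nM in this assay. Compound 1 `CCCCCCOc1cccc(O)c1C(=O)/C=C/c1ccc(O)cc1` reaches only an assay limit, > 30000 nM, in this assay. Of the two numbers shown, compound 3 holds the lower one; its nearest neighbour is compound 2, a gap beyond the scatter, while compound 1 contributes a limit rather than a number. Going by the values given here, the single one-point step measured, an at least 8.7-fold lower number from compound 1 to compound 3 (0.94 log units; beyond the scatter), rests on that limit (the limit of > 30000 nM in this assay, at which 1 of the 3 values shown sits), so only its minimum size is known.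

Among the compounds with values here, compound 4 `CC(C)(C)CCOc1cccc(O)c1C(=O)/C=C/c1ccc(O)cc1` is still to be measured in this assay. neopentyl in place of cyclopentyl on a saturated chain carbon bound to an oxygen on an aromatic ring Compound 2 carries the same neopentyl group, but it differs from compound 4 in a second place too, so their values form no single-change step. Within the data shown here, no measured step covers the cyclopentyl-to-neopentyl exchange directly; the only step available, an at least 8.7-fold lower number from compound 1 to compound 3 (0.94 log units; beyond the scatter), shows that an acyclic pentyl chain in place of cyclopentyl on that carbon pushes the number past the limit. An acyclic neopentyl group is therefore expected to raise the number, though less than fully. The expected step is a 2.6-fold higher number from compound 3 to compound 4 (0.42 log units; beyond the scatter). Compound 4 is estimated at 9000 nM in this assay, within 3000 nM to 30000 nM.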

Compound 4, concentration for 50% growth inhibition: 2380 nM
The estimate for compound 4 lay 3.8-fold (0.58 log units) above the measured number; the measured number lies below the stated range.
By their numbers in this assay, from the lowest: compounds 4 and 3 (each within the scatter of the next); then compound 2. At a limit, above all of these: compound 1.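

In this assay, the step of a 1.4-fold lower number from compound 3 to compound 4 (0.16 log units; within the scatter) shows that the ring of cyclopentyl is not required on a saturated chain carbon bound to an oxygen on an aromatic ring, since the acyclic neopentyl group cannot be told apart from it within the scatter. Compound 1 stands at a limit, so the step of an at least 12-fold lower number from compound 1 to compound 4 (1.10 log units; beyond the scatter), with tert-butyl in place of butyl, gives only a minimum size, yet it sets the unbranched chain of compound 1 apart from the branched chain of compound 4 in this small set: the limit of > 30000 nM in this assay, at which 1 of the 4 values shown sits.

With the neopentyl group now held constant, the step of a 4.7-fold lower number from compound 2 to compound 4 (0.67 log units; beyond the scatter) also gives a single-change reading of hydroxy in place of carboxy on an aromatic carbon, and that step lies beyond the scatter.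

Going by these compounds, whether a cyclohexyl ring, a longer branched chain or a terminal amine at the same place would fit this reading remains open. Also open, on these data alone, is how a methoxy group or an amide would compare with hydroxy and carboxy on that aromatic carbon.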